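Adding a methyl group to compound 1

The source may hold more compounds than are shown below. What is called first, only, known or untested is meant among the compounds shown, and "the series" means these compounds.

In a functional assay on MCF7 cells (Homo sapiens) for inhibition, in the absence of a further agent (on this read-out higher numbers stand for weaker inhibition and lower numbers for stronger inhibition), compound 1 (`Cc1ccc(N)c2c(=O)cc(-c3ccc(N)c(F)c3)oc12`) gives 15 nM and stands second highest of three numbers. Compound 3 (`Nc1ccc(-c2cc(=O)c3c(N)ccc(F)c3o2)cc1`) lies lower at 6.9 nM and compound 2 (`Nc1ccc(-c2cc(=O)c3c(N)c(Cl)cc(Cl)c3o2)cc1`) lies higher at 53 nM in this assay, and both gaps from compound 1 are beyond the usual scatter.

Compound 4 (`Cc1cc(C)c2oc(-c3ccc(N)c(F)c3)cc(=O)c2c1N`) has methyl in place of hydrogen on an aromatic carbon of the core of compound 1, ortho to an amino group and meta to a methyl group (methyl in place of hydrogen on an aromatic carbon). For the measured compounds named here, no measured pair isolates this change. Going by the values given here, the nearest guide is compound 2 (53 nM), the only measured compound with a group other than hydrogen ortho to that amino group, and it has the highest number of the three. This is one compound with a different group, so the support is thin.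

The estimated move is a 2.7-fold higher number from compound 1 to compound 4 (0.43 log units; beyond the scatter) and points to weaker inhibition, a modest step beyond the scatter. For compound 4 the expected value is 40 nM with an estimated range of 10 nM to 150 nM in this assay.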

Compound 4, half-maximal inhibitory concentration: 36 nM
Compound 4: middle estimate off by 1.1-fold (0.05 log units), on the high side; the range from low to high includes it.
By their numbers in this assay, from the lowest: compound 3; then compound 1; then compounds 4 and 2 (each within the scatter of the next).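

In this assay, methyl in place of hydrogen on this aromatic carbon, ortho to an amino group and meta to a methyl group, gives a 2.4-fold higher number from compound 1 to compound 4 (0.38 log units; beyond the scatter). For the compounds shown here, this is the first direct reading of the position: the change is a modest loss of inhibition that lies beyond the scatter, not a loss of all measurable inhibition. No measurement at hand accounts for the step.

This remains a single step, with one group at one position on one background, so it gives no trend with group size or type. On these data alone, whether a methoxy group, a hydroxyl group or a longer chain such as ethyl would be accepted here stays open, as does whether methyl would give a similar step with the other substituents of the core changed.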